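The compounds below may be only part of what the source reports. "The series", "measured", "known", "first", "only" and "open" are said of these compounds alone.

Working notes on the series, measured in an assay on microsomes from intestinal mucosa for inhibition of acyl-CoA:cholesterol acyltransferase (Oryctolagus cuniculus); a higher number here means a weaker inhibitor, a lower number a stronger inhibitor.

Compound 1 `CCCCCCCCCCCCCCCCS(=O)(=O)Nc1c(OC)cc(OC)cc1OC` gives 690 nM in this assay. Compound 2 `CCCCCCCCCCCCCCCCCCSC(=O)Nc1c(C)cccc1C` reaches only a limit of the assay, > 10000 nM, so no number stands for it; this is the case described by the limit of > 10000 nM in this assay, at which 1 of the 3 values shown sits. Compound 3 `CCCCCCCC/C=C\CCCCCCCCNC(=O)Nc1c(C)cc(C)cc1C` gives 2900 nM in this assay, which is the higher of the two actual numbers; compound 1, the nearest, sits lower, and that gap lies beyond the usual scatter of repeated measurements.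

Among the measured compounds shown here, no pair of measured compounds differs in only one place, so no single structural step has yet been measured in this assay. Compound 4 `CCCCCCCC/C=C\CCCCCCCCNC(=O)Nc1c(CC)cccc1C(C)C` is the next compound, differing from compound 3 by 2-ethyl-6-isopropylphenyl in place of 2,4,6-trimethylphenyl on an amide-type nitrogen. The measured compounds give no direct guide to the size of such a change, so the expectation is a modest move to a lower number, possibly not beyond the scatter. The expected change is a 1.9-fold lower number from compound 3 to compound 4 (0.29 log units; within the scatter). Compound 4 is expected to give 1500 nM in this assay, with a range from 400 nM to 6000 nM.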

Compound 4, half-maximal inhibitory concentration: 37 nM
Estimate against measurement, compound 4: 41-fold (1.61 log units) above; the whole stated range lies above it.
By their numbers in this assay, from the lowest: compound 4; then compound 1; then compound 3. At a limit, above all of these: compound 2.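

In this assay the aryl group on the amide-type nitrogen turns out to be a strong lever: 2-ethyl-6-isopropylphenyl in place of 2,4,6-trimethylphenyl gives a 78-fold lower number from compound 3 to compound 4 (1.89 log units; beyond the scatter), a large step. Among the compounds shown here, this is the first change read at a single place, with the chain and the rest of the structure shared, so the whole move belongs to the exchange of these two aryl groups; the earlier compounds differ from one another in more than one place and could not show this. For the compounds shown here, nothing measured so far bears on why this exchange has such an effect.

Which part of the exchange carries the step stays open: the ethyl group, the isopropyl group, or the loss of the methyl groups of 2,4,6-trimethylphenyl. Also open, on these data alone, is whether a phenyl ring with two isopropyl groups, or one carrying an amine, would hold the low number of compound 4, and whether the same aryl exchange would act alike with a shorter chain or with the sulfonyl link of compound 1.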